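The compounds below may be only part of what the source reports. "The series", "measured", "known", "first", "only" and "open" are said of these compounds alone.

Compound 1 `CC(C)(CCCCOc1cc(-c2ccc(C(F)(F)F)cc2)c2ccccc2n1)C(=O)O` and compound 2 `Cc1ccc(-c2cc(OCCCCC(C)(C)C(=O)O)nc3ccccc23)cc1` share one core and differ in a single group. In an assay on membranes from spleen (Cavia porcellus) for binding affinity to leukotriene B4 receptor 1 (Homo sapiens) (on this read-out higher numbers stand for weaker inhibition and lower numbers for stronger inhibition), compound 1 gives 300 nM, while compound 2 gives 30 nM. Going by the values given here, compound 2 thus holds the lowest of the two numbers so far; the step between them is a 10-fold lower number from compound 1 to compound 2 (1.00 log units; beyond the scatter). Compound 3 `COc1cccc(-c2cc(OCCCCC(C)(C)C(=O)O)nc3ccccc23)c1` carries 3-methoxyphenyl in place of 4-methylphenyl on an aromatic carbon. Among the compounds with values here, no measured step swaps these two groups, so only a 10-fold lower number from compound 1 to compound 2 (1.00 log units; beyond the scatter) speaks here, and it shows that a change at this place can move the number well beyond the scatter. A modest weakening is expected, a 2.7-fold higher number from compound 2 to compound 3 (0.43 log units; beyond the scatter). Compound 3 is estimated at 80 nM, between 20 nM and 400 nM.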

Compound 3, half-maximal inhibitory concentration: 300 nM
Estimate against measurement, compound 3: 3.8-fold (0.57 log units) below, within the range that was stated.
By their numbers in this assay, from the lowest: compound 2; then compounds 1 and 3 (each within the scatter of the next).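

In this assay, replacing 4-methylphenyl with 3-methoxyphenyl gives a clear loss (a 10-fold higher number from compound 2 to compound 3 (1.00 log units; beyond the scatter)), so a second kind of change at this position moves the number beyond the scatter. Replacing 4-(trifluoromethyl)phenyl with 3-methoxyphenyl gives (no change at the digits printed from compound 1 to compound 3 (within the scatter)), leaving 4-methylphenyl alone at the lower number among these three groups. No supporting data explain this difference. Still open, on these data alone, is whether the methoxy group itself or its place on the phenyl ring matters more; 4-methoxyphenyl and 3-methylphenyl would separate the two. As far as these compounds go, how an unsubstituted phenyl or an aminophenyl would behave here also remains unknown.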